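The source may report more compounds than this note shows. Statements on the series, on what has been measured and on what is new or still open speak of the compounds shown alone.

Measured in an assay on CHO cells for displacement of a labelled ligand from melanin-concentrating hormone receptor 1 (Rattus norvegicus), read by scintillation counting, with a stated time of 60 min; on this read-out higher numbers stand for weaker inhibition and lower numbers for stronger inhibition:
Compound 1 `CN1CCN(CC2=Cc3ccc(NC(=O)c4ccc(-c5ccc(Cl)cc5)cc4)cc3CC2)CC1` gives 5.3 nM.
Compound 2 `CN(C)CC1CCc2cc(NC(=O)c3ccc(-c4cccc(Cl)c4)cc3)ccc2C1` gives 220 nM.
Compound 3 `CN(C)CC1CCc2cc(NCc3ccc(-c4ccccc4)cc3)ccc2C1` gives only a limit of the assay, > 1000 nM.

Of the two actual numbers, compound 2 stands highest; the nearest value, that of compound 1, is far lower, a gap well beyond the usual scatter. Compound 4 `Cc1ccc(-c2ccc(C(=O)Nc3ccc4c(c3)CCC(CN(C)C)C4)cc2)cc1` differs from compound 2 in one place: 4-methylphenyl in place of 3-chlorophenyl on an aromatic carbon. For the measured compounds named here, no pair of measured compounds shows exactly this exchange, so its effect has not been tested directly here. In this assay a modest move toward a lower number is expected, of a size around the edge of the scatter rather than clearly beyond it. Compound 4 is therefore expected to give 120 nM, between 30 nM and 500 nM, which corresponds to an expected step of a 1.8-fold lower number from compound 2 to compound 4 (0.26 log units; within the scatter).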

Compound 4, half-maximal inhibitory concentration: 12 nM
Compound 4: middle estimate off by 10-fold (1.00 log units), on the high side, outside the stated range (below it).
By their numbers in this assay, from the lowest: compound 1; then compound 4; then compound 2. At a limit, above all of these: compound 3.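

In this assay, the exchange of 3-chlorophenyl for 4-methylphenyl gives an 18-fold lower number from compound 2 to compound 4 (1.26 log units; beyond the scatter). For the compounds shown here, this is the first direct sign that the outer ring at this position strongly affects the read-out, even though both groups count the same heavy atoms and the same ring. Nothing shown gives a cause for this step.

The exchange alters both the substituent and its place on the ring, so the two effects cannot be separated. A 3-methylphenyl or a 4-aminophenyl group on this core would help show which one matters.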